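Chloro in Place of Methyl: What Compound 4 Should Show

The compounds below may be only part of what the source reports. "The series", "measured", "known", "first", "only" and "open" are said of these compounds alone.

Measured compounds:
compound 1, `O=C(COc1ccc(Cl)cc1)Nc1c(-c2ccccc2)[nH]c2ccccc12`, gives 32000 nM
compound 2, `CCOC(=O)C1CCN(C(=S)Sc2c(-c3ccc(Br)cc3)[nH]c3ccc(C)cc23)CC1`, gives 37000 nM
compound 3, `CCN(CC)C(=S)Sc1c(-c2ccc(Br)cc2)[nH]c2ccc(Br)cc12`, gives 33000 nM

These three numbers come from a functional assay on B16-F10 cells (Mus musculus) for inhibition, read by MTT assay, with a stated time of 72 h; a higher number here means a weaker inhibitor of growth, a lower number a stronger inhibitor of growth. In this assay compound 2 gives 37000 nM, the highest of the three numbers, yet its nearest neighbour, compound 3 with 33000 nM, and the furthest, compound 1 with 32000 nM, both lie within the scatter of it, so no order among the three can be read from these values.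

The unmeasured compound 4, `CCOC(=O)C1CCN(C(=S)Sc2c(-c3ccc(Br)cc3)[nH]c3ccc(Cl)cc23)CC1`, differs from compound 2 in one place: chloro in place of methyl on an aromatic carbon. Going by the values given here, no pair of measured compounds differs in a single place, so there is no measured step to lean on. Compound 3 carries a bromo at a position of the same kind and gives a number within the scatter of compound 2, which is the only hint at hand.

The step from compound 2 to compound 4 is therefore expected to be small, a 1.1-fold lower number from compound 2 to compound 4 (0.04 log units; within the scatter), in no direction beyond the scatter. For compound 4 in this assay the estimate is 34000 nM, expected to fall between 15000 nM and 75000 nM.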

Compound 4, concentration for 50% growth inhibition: 21000 nM
Compound 4: the middle estimate sits 1.6-fold (0.21 log units) above what was measured; measured number inside the range.
By their numbers in this assay, from the lowest: compounds 4, 1, 3 and 2 (each within the scatter of the next).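

Chloro in place of methyl on this aromatic carbon gives, in this assay and as the first step here between compounds that differ in one place, a 1.8-fold lower number from compound 2 to compound 4 (0.25 log units; within the scatter) and so compound 2 and compound 4 cannot be put in order. The earlier compounds shown here could only hint at this, since none of them differed from another in a single place, whereas this pair shows directly that the exchange of one group for the other at this carbon, with the rest of the structure held the same, produces no difference that stands clear of the usual scatter of repeated measurements. Nothing at hand measures any property of methyl or chloro in these compounds, so the data offer no explanation for the size of this step.

What the compounds shown leave open is whether anything placed on this carbon can move the number beyond the scatter, for instance an amine, a carboxylic acid, a methoxy group or a longer chain. As far as these compounds go, it is also open whether chloro in place of methyl would give a similarly small step if the rest of the structure were different.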